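This account rests on a few compounds, and the source may have more. Where it says the series, first, only, none or still open, it means among the compounds named here.

Among the measured compounds shown here, compound 2 `Fc1cnc(Nc2cc3[nH]c(-c4cccc(C(F)(F)F)c4)nc3cn2)c(F)c1` is one of only two compounds with a number here. In an ADME assay on microsomes from liver (Mus musculus) for metabolic stability, read by LC-MS, with a stated time of 30 min, tested at 0.1 uM (on this read-out lower numbers stand for a less stable compound and higher numbers for a more stable compound), compound 2 gives 49%, the lower of the two, while compound 1 `FC(F)(F)c1cccc(-c2nc3cnc(Nc4cccnn4)cc3[nH]2)c1` gives 51%, a gap that lies within the scatter. For the measured compounds named here, the single measured step that touches the same position, a number 2 percentage points lower from compound 1 to compound 2 (within the scatter), exchanged one six-membered heteroaryl on the ring nitrogen for another and did not leave the scatter. Compound 3 `N#Cc1ccc(Nc2cc3[nH]c(-c4cccc(C(F)(F)F)c4)nc3cn2)nc1` differs from compound 2 by 5-cyanopyridin-2-yl in place of 3,5-difluoropyridin-2-yl on a nitrogen on an aromatic ring, again an exchange of one six-membered heteroaryl for another on that nitrogen. Going by the values given here, with only one comparable step available, and that one within the scatter, the expected step in this assay is a number 1 percentage points lower from compound 2 to compound 3 (within the scatter), nothing beyond the usual spread. For compound 3 the estimate in this assay is therefore 48%, with a range from 30% to 66%.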

Compound 3, percent of the compound remaining: 47%
Beside the measured number, compound 3's estimate is 1 percentage points above it, and the stated range covers the measured number.
By their numbers in this assay, from the lowest: compounds 3, 2 and 1 (each within the scatter of the next).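

In this assay, putting 5-cyanopyridin-2-yl in place of 3,5-difluoropyridin-2-yl on the nitrogen gives a small step (a number 2 percentage points lower from compound 2 to compound 3 (within the scatter)), and the same group in place of pyridazin-3-yl gives another (a number 4 percentage points lower from compound 1 to compound 3 (within the scatter)). Unlike the earlier pair, the three compounds now show that a ring carrying a nitrile also stays within the scatter of both other heteroaryl groups, so all three exchanges at this position leave the read-out effectively unmoved. Nothing available explains why these groups read alike. The compounds shown stay with six-membered aromatic rings on this nitrogen, so it remains open whether a saturated amine such as piperidine, or a ring bearing a carboxylic acid, would step beyond the scatter. From the compounds shown here alone, whether any change elsewhere on the shared core would do so also remains open.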